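A second methoxy group on a weakly active dienone

The source may hold more compounds than are shown below. What is called first, only, known or untested is meant among the compounds shown, and "the series" means these compounds.

Measured so far:
compound 1 `COc1ccccc1/C=C/C(=O)/C=C/c1ccc(OCc2cn(CCOc3cc(=O)oc4ccccc34)nn2)c(OC)c1` — 11%
compound 2 `COc1ccccc1/C=C/C(=O)/C=C/c1ccc(OCc2cn(CCCCOc3cc(=O)oc4ccccc34)nn2)c(OC)c1` — "not active" (no number reported)

Going by the values given here, in a functional assay on PC-3 cells (Homo sapiens) for inhibition, read by sulforhodamine B assay, with a stated time of 48 h, tested at 50 uM (a lower number here means less inhibition of growth, a higher number more inhibition of growth at the concentration tested), compound 1 gives 11%, which is the only number reported here. Among the compounds with values here, compound 2, which carries a longer linker to the coumarin-bearing side of the core, is reported in this assay as "not active" (no number reported) without a number, so no step between measured compounds can be read from these two entries. Compound 3 `COc1ccc(/C=C/C(=O)/C=C/c2ccc(OCc3cn(CCOc4cc(=O)oc5ccccc45)nn3)c(OC)c2)cc1OC` keeps the core of compound 1 and differs from it only in the change (3,4-dimethoxyphenyl in place of 2-methoxyphenyl on a double-bonded chain carbon bound to a double-bonded chain carbon). Since no measured step of comparable kind is shown, the size of the step from compound 1 to compound 3 in this assay can only be guessed, and a change of this modest kind is expected to stay within the scatter, with no clear direction. Compound 3 is therefore expected to give 14% in this assay, with a range from 0% to 32%, which is the step of a number 3 percentage points higher from compound 1 to compound 3 (within the scatter) that this estimate means.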

Compound 3, percent growth inhibition at one concentration: 19%
The estimate for compound 3 lay 5 percentage points below the measured number, within the range that was stated.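

In this assay the change gives a number 8 percentage points higher from compound 1 to compound 3 (within the scatter) and so shows that, on a double-bonded chain carbon bound to a double-bonded chain carbon, 3,4-dimethoxyphenyl can stand in place of 2-methoxyphenyl without a step beyond the scatter. The second methoxy group therefore does not separate the two compounds in this assay at the concentration tested. No measurement shown here bears on the reason for this result.

Compound 2 carries no number, so steps involving it cannot be read. From the compounds shown here alone, it remains open whether an amine or a carboxylic acid on this phenyl ring in place of the methoxy groups would move growth inhibition beyond the scatter.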